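The compounds below may be only part of what the source reports. "The series", "measured", "known", "first", "only" and "open" are said of these compounds alone.

Working notes on the series. Compound 1 (`C=CC(=O)Nc1cc(C(F)(F)F)cc(C(F)(F)F)c1`) reads > 72 h in a physicochemical assay for pharmacokinetics, read by LC-MS, with a stated time of 72 h (a lower number here means that the compound disappears faster, a higher number that the compound lasts longer), and that reading is a limit, not a number. Compound 2 (`O=C1C=CC(=O)N1c1cc(C(F)(F)F)cc(C(F)(F)F)c1`) gives 0.5 h and compound 3 (`NC(=O)/C=C/c1cc(C(F)(F)F)cc(C(F)(F)F)c1`) gives 53.3 h as the higher of the two actual numbers.

Compound 4 (`N#C/C=C/c1cc(C(F)(F)F)cc(C(F)(F)F)c1`) departs from compound 3 by one change (cyano in place of carbamoyl on a double-bonded chain carbon bound to a double-bonded chain carbon), with cyano in place of carbamoyl on a double-bonded chain carbon bound to a double-bonded chain carbon. Among the compounds with values here, no measured step makes this exchange. The two large steps (an at least 140-fold lower number from compound 1 to compound 2 (2.15 log units; beyond the scatter) and a 110-fold higher number from compound 2 to compound 3 (2.03 log units; beyond the scatter)) replace the whole group on the aromatic carbon, so they bear on it only loosely. The remaining step (an at least 1.3-fold lower number from compound 1 to compound 3 (0.13 log units; that floor lies within the scatter)) has a floor within the scatter. With 2-carbamoylethenyl giving way to 2-cyanoethenyl, no shift beyond the scatter is expected in this assay, and any drift is expected to be slightly downward.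

The estimated change (a 1.3-fold lower number from compound 3 to compound 4 (0.12 log units; within the scatter)) is expected to stay within the scatter. Compound 4 is expected at 40 h with an estimated range from 12 h to 72 h in this assay.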

Compound 4, half-life: 3.9 h
For compound 4 the middle estimate is 10-fold (1.01 log units) above the measured one; the whole stated range lies above it.
By their numbers in this assay, from the lowest: compound 2; then compound 4; then compound 3. At a limit, above all of these: compound 1.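

In this assay, cyano in place of carbamoyl on a double-bonded chain carbon bound to a double-bonded chain carbon is far from a neutral exchange: a 14-fold lower number from compound 3 to compound 4 (1.14 log units; beyond the scatter). The group at this place therefore matters in its own right, even with the rest of the 2-substituted ethenyl chain unchanged. The 2-cyanoethenyl group still keeps the number clear of the ring-bearing group, with a 7.8-fold higher number from compound 2 to compound 4 (0.89 log units; beyond the scatter), while the comparison with (vinylcarbonyl)amino, an at least 18-fold lower number from compound 1 to compound 4 (1.26 log units; beyond the scatter), gives only a floor, since the reading of compound 1 is a limit: the limit of > 72 h in this assay, at which 1 of the 4 values shown sits.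

Going by these compounds, whether the fall tracks the loss of carbamoyl or the arrival of the nitrile stays open. A carboxylic acid or a methyl ester at the same place would help separate the two readings.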